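Carbamate variation on a tricyclic glucose-dependent insulinotropic receptor agonist

The source may report more compounds than this note shows. Statements on the series, on what has been measured and on what is new or still open speak of the compounds shown alone.

Compound 1: `CC(C)(C)OC(=O)N1CCC(Oc2cccc3c2ccn3-c2ccc(S(C)(=O)=O)cc2)CC1`, 631 nM
Compound 2: `CC(C)OC(=O)N1CCC(Oc2ncnc3c2CCN3c2ccc(S(C)(=O)=O)cc2)CC1`, 126 nM
Compound 3: `CC(C)(C)OC(=O)N1CCC(Oc2ncnc3c2CCN3c2ccc(S(C)(=O)=O)cc2F)CC1`, 20 nM

Of the compounds shown here, three have been tested in a functional assay on CHO-K1 cells for agonist activity at Glucose-dependent insulinotropic receptor (Homo sapiens), read by a luciferase reporter, with a stated time of 5 h; a higher number here means that more compound is needed for the effect, a lower number that less compound is needed. Compound 3 stands at the lowest of the three numbers: the nearest is compound 2, whose number is higher by a margin that lies beyond the usual scatter, and the furthest is compound 1, higher still by a margin also beyond the scatter. Compound 2 and compound 1 each differ from compound 3 in more than one place, so their values show only where each stands, not what any single change does.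

The step now followed leads from compound 3 to compound 4, `COCCOC(=O)N1CCC(Oc2ncnc3c2CCN3c2ccc(S(C)(=O)=O)cc2F)CC1`, which has not yet been measured. The change is 2-methoxyethyl in place of tert-butyl on an oxygen next to a carbonyl group.

For the measured compounds named here, no step between measured compounds isolates a change at this position, so the expectation rests on the numbers alone. The author expects the number to rise somewhat, a step of a 3.0-fold higher number from compound 3 to compound 4 (0.48 log units; beyond the scatter), most likely modest but possibly beyond the scatter. For compound 4 the estimate in this assay is 60 nM, with a range from 15 nM to 250 nM.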

Compound 4, half-maximal effective concentration: 316 nM
Estimate against measurement, compound 4: 5.3-fold (0.72 log units) below, outside the stated range (above it).
By their numbers in this assay, from the lowest: compound 3; then compound 2; then compounds 4 and 1 (each within the scatter of the next).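

For the compounds shown here, this is the only single-place comparison, and in this assay replacing tert-butyl with 2-methoxyethyl on an oxygen next to a carbonyl group gives a 16-fold higher number from compound 3 to compound 4 (1.20 log units; beyond the scatter), a large step that lies beyond the scatter. The earlier compounds shown here could not show this, since each differed from compound 3 in more than one place; this step shows that the position does not tolerate every group of a given heavy-atom count, for tert-butyl and 2-methoxyethyl both count the same number of heavy atoms, and they differ in that one carbon gives way to an oxygen and the chain is no longer branched at the carbon on the oxygen. No measurement at hand bears on the reason for the size of this step.

The compounds shown leave open whether the rise goes with the ether oxygen or with the loss of the tert-butyl shape, a question that an all-carbon chain such as n-butyl at the same place could separate from the first. They also leave open how a cyclopropylmethyl group or a longer ether chain would read here, so the step describes one exchange and not a trend at this position.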